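The source may hold more compounds than are shown below. What is called first, only, known or untested is meant among the compounds shown, and "the series" means these compounds.

Of the compounds shown here, three have so far been tested in a functional assay on KOPN-8 cells (Homo sapiens) for antiproliferative activity, with a stated time of 72 h (on this read-out lower numbers stand for an effect already at smaller amounts and higher numbers for an effect only at larger amounts of compound), and each of them gave only a limit of the assay rather than a number. Compound 1, `COc1ccc(-c2cc(=O)c3c(OC)cc(OC)cc3n2S(=O)(=O)Cc2ccccc2)cc1`, gives > 34400 nM, which is a limit. Compound 2, `COC(=O)c1cc(=O)c2cc(NC(=O)Nc3ccc(Cl)c(C(F)(F)F)c3)ccc2[nH]1`, gives > 6350 nM, also a limit. Compound 3, `COC(=O)c1cc(=O)c2cc(NC(=O)Nc3ccc(Cl)c(Cl)c3)ccc2[nH]1`, gives > 6350 nM, again a limit. Among the measured compounds shown here, the one measured step, a step that the two limits leave unreadable from compound 2 to compound 3, therefore shows neither a size nor a direction. Compound 4, `COC(=O)c1cc(=O)c2cc(NC(=O)Nc3ccc(F)c(Cl)c3)ccc2[nH]1`, differs from compound 3 by fluoro in place of chloro on an aromatic carbon. With only limits to go on (the limit of > 34400 nM in this assay, at which 1 of the 3 values shown sits, (the limit of > 6350 nM in this assay, at which 2 of the 3 values shown sit)), no step beyond the scatter can be expected in this assay (this assay); the expected step is a step that the limit leaves unreadable from compound 3 to compound 4. Compound 4 is thus expected to give about 8000 nM, between 3000 nM and 30000 nM, most likely again only as a limit.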

Compound 4, half-maximal effective concentration: > 6350 nM
Compound 4 was reported as a limit; the forecaster's own chance of this, stated with the estimate: 85%; the middle value does not contradict the limit.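

Compound 3 and compound 4 both gave only a limit of the assay, so no step can be read between them. The compounds shown leave open whether fluoro or chloro at this place makes any difference to the effect on these cells.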